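Capping the hydroxy group of compound 3 with methyl

The compounds below may be only part of what the source reports. "The series", "measured", "known", "first", "only" and "open" are said of these compounds alone.

Compound 1 `Nc1nc(N)c2cc(CSC(=S)N3CCN(C4CCCCC4)CC3)ccc2n1` gives 6800 nM
Compound 2 `Nc1nc(N)c2cc(CSC(=S)N3CCN(c4ccccc4)CC3)ccc2n1` gives 2950 nM
Compound 3 `Nc1nc(N)c2cc(CSC(=S)N3CCN(c4ccc(O)cc4)CC3)ccc2n1` gives 5090 nM

In a functional assay on MCF7 cells (Homo sapiens) for antiproliferative activity, read by MTT assay, with a stated time of 72 h (a lower number here means a stronger inhibitor, a higher number a weaker inhibitor), compound 3 (5090 nM) lies within the scatter of both compound 1 (6800 nM) and compound 2 (2950 nM), although those two differ from each other by a modest step, a 2.3-fold lower number from compound 1 to compound 2 (0.36 log units; beyond the scatter), beyond the scatter.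

Compound 4 `COc1ccc(N2CCN(C(=S)SCc3ccc4nc(N)nc(N)c4c3)CC2)cc1` has methyl in place of hydrogen on an oxygen on an aromatic ring, hydroxy to methoxy (methyl in place of hydrogen on an oxygen on an aromatic ring). Among the measured compounds shown here, no measured step makes this exact change. The closest is hydroxy in place of hydrogen on an aromatic carbon, a 1.7-fold higher number from compound 2 to compound 3 (0.24 log units; within the scatter), which stays within the scatter. The change of cyclohexyl to 4-hydroxyphenyl, a 1.3-fold lower number from compound 1 to compound 3 (0.13 log units; within the scatter), does too. These small steps give no reason to expect a large shift in this assay and no firm direction. The estimated step is a 1.3-fold lower number from compound 3 to compound 4 (0.10 log units; within the scatter) and so none beyond the scatter is expected. The expected value for compound 4 is 4000 nM with an estimated range from 1800 nM to 9000 nM.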

Compound 4, half-maximal inhibitory concentration: 1580 nM
The estimate for compound 4 lay 2.5-fold (0.40 log units) above the measured number; measured number outside the range, below it.
By their numbers in this assay, from the lowest: compounds 4, 2, 3 and 1 (each within the scatter of the next, the first and the last beyond it).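

In this assay methylation of the hydroxy group on the aromatic ring brings a step beyond the scatter (a 3.2-fold lower number from compound 3 to compound 4 (0.51 log units; beyond the scatter)), whereas adding hydroxy to the phenyl group of compound 2 had stayed within it. Methoxy in place of hydrogen on the same aromatic carbon remains within the scatter (a 1.9-fold lower number from compound 2 to compound 4 (0.27 log units; within the scatter)), so the capped compound cannot be separated from the unsubstituted phenyl compound, and the clearest gain from this substituent appears against the hydroxy compound and against cyclohexyl (a 4.3-fold lower number from compound 1 to compound 4 (0.63 log units; beyond the scatter)). Nothing available explains why capping the oxygen with methyl moves the number. The compounds shown leave open whether a longer chain on the oxygen, such as ethoxy, would go with a lower or a higher number. They also leave open how an amine in place of the hydroxy group would compare with methoxy.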